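A few compounds are considered here, and "the series" means these few. Any claim that something is new, unique, unknown or untested is made for them only; others in the source may bear on it.

Series notes on cytotoxicity. Compound 1 `CC(C)N(Cc1cccc(OCCCCCC(=O)O)c1)C(=O)c1ccc(-c2cccc(N(C)C)c2)cc1` is the parent acid. In an ADME assay on HEK293 cells (Homo sapiens) for cytotoxicity, read by CellTiter-Glo and resazurin assay, with a stated time of 72 h (on this read-out higher numbers stand for an effect only at larger amounts of compound and lower numbers for an effect already at smaller amounts), compound 1 gives only the limit of > 26000 nM. Compound 2 `CC(C)N(Cc1cccc(OCCCCCC(=O)O)c1)C(=O)c1ccc(-c2ccoc2)cc1` carries furan-3-yl in place of 3-(dimethylamino)phenyl on an aromatic carbon. In this assay compound 2 likewise stops at the limit of > 26000 nM. Compound 3 `CCOC(=O)CCCCCOc1cccc(CN(C(=O)c2ccc(-c3cccc(N(C)C)c3)cc2)C(C)C)c1` carries ethyl in place of hydrogen on an oxygen next to a carbonyl group. In this assay compound 3 again reaches only the limit of > 26000 nM. Compound 3 thus stands exactly where the rest of the series stands: every value seen so far is a limit and not a number, as the limit of > 26000 nM in this assay, at which 3 of the 3 values shown sit, records. Both measured steps, a step that the two limits leave unreadable from compound 1 to compound 2 and a step that the two limits leave unreadable from compound 1 to compound 3, rest on limits at each end and give no readable size.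

Compound 4 `CCOC(=O)CCCCCOc1cccc(CN(C(=O)c2ccc(-c3ccc(C(C)=O)s3)cc2)C(C)C)c1` is not yet measured in this assay. It differs from compound 3 by 5-acetylthiophen-2-yl in place of 3-(dimethylamino)phenyl on an aromatic carbon. The change sits on the same aromatic carbon as the swap from compound 1 to compound 2, which gave a step that the two limits leave unreadable from compound 1 to compound 2, while the ethyl ester of compound 3 is kept. Neither measured step bears a readable size, so no direction can be taken from them. The expected step that the limit leaves unreadable from compound 3 to compound 4 is none beyond the scatter, with a limit again the most likely outcome. Compound 4 is estimated at 40000 nM, within 15000 nM to 120000 nM.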

Compound 4, half-maximal effective concentration: > 26000 nM
Compound 4 gave a limit, no number; the forecaster's own chance of this, stated with the estimate: 80%; the middle value does not contradict the limit.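

In this assay compound 4 gives > 26000 nM, which is a limit and not a number. With compound 3 also resting on a limit, no new step can be read from compound 3 to compound 4. The compounds shown leave open what half-maximal effective concentration any of them has, and whether the swaps on the aromatic carbon or the ethyl ester change it.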